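Three Measured Amides and One Still Awaiting a Number

A few compounds are considered here, and "the series" means these few. Any claim that something is new, unique, unknown or untested is made for them only; others in the source may bear on it.

Compound 1 (`CC(C)(C)c1cc(NC(=O)[C@@H]2CCCCN2C(=O)C2CCOCC2)no1`): 48 ug/mL in a physicochemical assay for solubility, read by HPLC, at pH 6.8; a lower number here means a less soluble compound, a higher number a more soluble compound
Compound 2 (`CC(C)(C)c1cc(NC(=O)[C@@H]2CCCCN2C(=O)C2CCS(=O)(=O)CC2)no1`): 67 ug/mL
Compound 3 (`CC(C)(C)c1cc(NC(=O)[C@@H]2CCCCN2C(=O)N2CCCCC2)no1`): 49 ug/mL

Compound 4 (`CC(=O)N1CCN(C(=O)N2CCCC[C@H]2C(=O)Nc2cc(C(C)(C)C)on2)CC1`) has not yet been measured. Within the three numbers in hand, compound 3 stands second highest; its nearest neighbour is compound 1, with the step of a 1.0-fold higher number from compound 1 to compound 3 (0.01 log units; within the scatter), and its furthest is compound 2, with the step of a 1.4-fold lower number from compound 2 to compound 3 (0.14 log units; within the scatter). Every pairing of the three therefore lies inside the scatter of this assay.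

The change that leads to compound 4 is 4-acetylpiperazin-1-yl in place of piperidin-1-yl on a carbonyl carbon. Two earlier steps bear on it, both at the same carbonyl carbon of the shared core: a 1.4-fold higher number from compound 1 to compound 2 (0.14 log units; within the scatter), and a 1.0-fold higher number from compound 1 to compound 3 (0.01 log units; within the scatter). Neither exchange of the group on that carbonyl moved the number beyond the scatter, whether the group gained an acceptor or lost one. On that basis compound 4 is expected to show no step beyond the scatter, with the estimated change being a 1.2-fold higher number from compound 3 to compound 4 (0.09 log units; within the scatter). The estimate for compound 4 in this assay is therefore 60 ug/mL, within a range from 30 ug/mL to 120 ug/mL.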

Compound 4, solubility: 62 ug/mL
The estimate for compound 4 lay 1.0-fold (0.01 log units) below the measured number; the range from low to high includes it.
By their numbers in this assay, from the lowest: compounds 1, 3, 4 and 2 (each within the scatter of the next).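

Placing 4-acetylpiperazin-1-yl in place of piperidin-1-yl on a carbonyl carbon adds a second ring hetero atom, an acetyl group and a hydrogen-bond acceptor, yet this assay records only a 1.3-fold higher number from compound 3 to compound 4 (0.10 log units; within the scatter) for this change. The larger group also stays within the scatter of both groups with a carbon at this attachment point, with a 1.1-fold lower number from compound 2 to compound 4 (0.03 log units; within the scatter) and a 1.3-fold higher number from compound 1 to compound 4 (0.11 log units; within the scatter) so that oxan-4-yl, 1,1-dioxothian-4-yl, piperidin-1-yl and 4-acetylpiperazin-1-yl cannot be told apart by this read-out in these four compounds. Nothing in hand accounts for this lack of separation, and no measurement explains any of these steps.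

The compounds shown leave open whether a carboxylic acid, an amine with a free nitrogen hydrogen or a longer alkyl chain on the same carbonyl carbon would give a step beyond the scatter. They also leave open whether a change elsewhere on the shared core, such as another group in place of the tert-butyl, would move the number when any of these four groups is present.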